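The compounds below may be only part of what the source reports. "The series", "measured", "known", "first", "only" and "open" are said of these compounds alone.

Measured compounds:
Compound 1, `Cc1c(F)c(Oc2cccc(C(=N)N)c2)nc(Oc2cccc(C(=O)O)c2)c1F`. In an assay on isolated protein for inhibition of serine protease 1 (Bos taurus) (on this read-out lower numbers stand for stronger inhibition and higher numbers for weaker inhibition), compound 1 gives > 5000 nM, which is a limit of the assay and not a number.
Compound 2, `Cc1c(F)c(Oc2cccc(C(=N)N)c2)nc(Oc2cccc(-n3ccnc3)c2)c1F`. In this assay compound 2 gives 4800 nM.
Compound 3, `Cc1c(F)c(Oc2cccc(OC(C)C)c2)nc(Oc2cccc(C(=N)N)c2)c1F`. In this assay compound 3 gives 2900 nM.

Compound 3 holds the lowest of the two numbers shown; its nearest neighbour is compound 2, and the step of a 1.7-fold lower number from compound 2 to compound 3 (0.22 log units; within the scatter) stays within the scatter. Compound 1 sits at the limit of > 5000 nM in this assay, at which 1 of the 3 values shown sits, so its distance to compound 3 is known only as a floor.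

Compound 4, `Cc1c(F)c(Oc2cccc(C(=N)N)c2)nc(Oc2cccc([S+]([O-])N(C)C)c2)c1F`, differs from compound 3 by a group of 5 heavy atoms (2 carbon, 1 nitrogen, 1 oxygen, 1 sulfur; no ring) in place of a group of 4 heavy atoms (3 carbon, 1 oxygen; no ring), on an aromatic carbon; the new group stands on an aromatic carbon of a six-membered aromatic ring of carbon only, meta to a large group. The measured steps that bear on this exchange all replace the group on that aromatic carbon of the shared core: an at least 1.0-fold lower number from compound 1 to compound 2 (0.01 log units; that floor lies within the scatter), an at least 1.7-fold lower number from compound 1 to compound 3 (0.23 log units; that floor lies within the scatter) and a 1.7-fold lower number from compound 2 to compound 3 (0.22 log units; within the scatter). None of them rises beyond the scatter, and two of them rest on a limit. Carboxy, 1H-imidazol-1-yl and isopropoxy thus give numbers in one narrow band in this assay, and the change to compound 4 is expected to behave the same way, with a 1.2-fold higher number from compound 3 to compound 4 (0.08 log units; within the scatter) not beyond the scatter. Compound 4 is therefore estimated at 3500 nM, within a range from 1500 nM to 9000 nM.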

Compound 4, inhibition constant: 2400 nM
For compound 4 the middle estimate is 1.5-fold (0.16 log units) above the measured one; the range from low to high includes it.
By their numbers in this assay, from the lowest: compounds 4, 3 and 2 (each within the scatter of the next). At a limit, above all of these: compound 1.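

In this assay, the new group of 5 heavy atoms, with its sulfur and nitrogen, stays level with isopropoxy, at a 1.2-fold lower number from compound 3 to compound 4 (0.08 log units; within the scatter), and level with 1H-imidazol-1-yl, at a 2.0-fold lower number from compound 2 to compound 4 (0.30 log units; within the scatter), so a group without a ring and one with a ring both fit the same narrow band at this aromatic carbon. For the compounds shown here, what the earlier compounds did not show is a step at this position that clears the scatter, and the exchange of carboxy for the new group gives one, at an at least 2.0-fold lower number from compound 1 to compound 4 (0.31 log units; beyond the scatter). Going by these compounds, that step is only a floor, and its true size stays unknown, since the value of compound 1 is a limit of the assay and not a number: the limit of > 5000 nM in this assay, at which 1 of the 4 values shown sits.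

The compounds shown leave open how far carboxy really lies from the other three groups, and whether any group at this place can move the number beyond the scatter of that band. A primary amine, a simple amide or a longer alkyl chain on this aromatic carbon would test whether the band holds.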